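The source may report more compounds than this note shows. Statements on the series, on what has been measured and on what is new or still open speak of the compounds shown alone.

Measured in a functional assay on SMMC-7721 cells (Homo sapiens) for cytotoxicity, read by MTT assay, with a stated time of 72 h; a higher number here means a weaker inhibitor, a lower number a stronger inhibitor:
- compound 1 `O=C1C(=Cc2ccc(F)cc2F)C(=O)N(c2ccc(Cl)cc2)N1c1ccc(Cl)cc1`: 35800 nM
- compound 2 `O=C1C(=Cc2ccco2)C(=O)N(c2ccc(Cl)cc2)N1c1ccc(Cl)cc1`: 19500 nM
- compound 3 `O=C1C(=Cc2c[nH]c3ccccc23)C(=O)N(c2ccc(Cl)cc2)N1c1ccc(Cl)cc1`: 19600 nM

The value of compound 3 cannot be separated from the other two, as both steps to it lie within the scatter: a 1.8-fold lower number from compound 1 to compound 3 (0.26 log units; within the scatter), and a 1.0-fold higher number from compound 2 to compound 3 (0.00 log units; within the scatter).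

The next analogue is compound 4 `O=C1C(=Cc2ccccc2)C(=O)N(c2ccc(Cl)cc2)N1c1ccc(Cl)cc1`, with phenyl in place of 1H-indol-3-yl on a double-bonded chain carbon bound to a double-bonded ring carbon.

All three measured changes at this place bear on it. The third, a 1.8-fold lower number from compound 1 to compound 2 (0.26 log units; within the scatter), also stays within the scatter, so no step beyond the scatter is expected in this assay.

The expected change is a 1.2-fold higher number from compound 3 to compound 4 (0.09 log units; within the scatter).

For compound 4 the estimated value is 24000 nM, with an expected range of 12000 nM to 48000 nM.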

Compound 4, half-maximal inhibitory concentration: 26200 nM
For compound 4 the middle estimate is 1.1-fold (0.04 log units) below the measured one; the range from low to high includes it.
By their numbers in this assay, from the lowest: compounds 2, 3, 4 and 1 (each within the scatter of the next).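

Read in this assay the plain phenyl separates from none of the other three groups on a double-bonded chain carbon bound to a double-bonded ring carbon (a 1.3-fold higher number from compound 3 to compound 4 (0.13 log units; within the scatter)) (a 1.3-fold higher number from compound 2 to compound 4 (0.13 log units; within the scatter)) (a 1.4-fold lower number from compound 1 to compound 4 (0.14 log units; within the scatter)). Dropping the hydrogen-bond donor of 1H-indol-3-yl or the fluorines of 2,4-difluorophenyl therefore produces no readable step, and the four aromatic groups at this place form one flat set. Nothing at hand accounts for this flatness.

Open, going by these compounds, is whether an amine or a carboxylic acid on the phenyl, or a longer chain in its place, would give a step beyond the scatter. Changes elsewhere on the shared core also remain open.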